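The source may report more compounds than this note shows. Statements on the series, on what has been measured and on what is new or still open speak of the compounds shown alone.

Compound 2 `CCCC(C)Nc1nc(C)nc2c(-c3c(C)cc(OC)cc3OC)c(C)nn12` gives 2.14 nM in an assay on cell membranes for displacement of a labelled ligand from corticotropin-releasing factor receptor 1 (Rattus norvegicus) (a lower number here means a stronger inhibitor, a higher number a weaker inhibitor), the lowest of the two numbers shown. Compound 1 `CCN(CC)c1nc(C)nc2c(-c3ccc(OC)c(C)c3C)c(C)nn12` gives 38.6 nM in this assay; this pair differs in more than one place, so only the two values can be set side by side, and the gap between them lies beyond the scatter. Compound 3 `C=CCN(CC=C)c1nc(C)nc2c(-c3c(C)cc(OC)cc3OC)c(C)nn12` has not been measured. Relative to compound 2 the change is diallylamino in place of (1-methylbutyl)amino on an aromatic carbon: the hydrogen-bond donor is lost and the aryl part stays the same. Among the compounds with values here, no measured pair shows this single change, so its size is not known from the data. The (1-methylbutyl)amino compound sits well below the diethylamino compound, but the two differ also in the aryl part, so that gap cannot be read as an amine effect. The expectation is a modest step upward, within or just beyond the scatter, so that a 2.8-fold higher number from compound 2 to compound 3 (0.45 log units; beyond the scatter) is the estimated step. Compound 3 is expected to give about 6 nM in this assay, with a range from 1.5 nM to 25 nM.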

Compound 3, half-maximal inhibitory concentration: 1 nM
Compound 3: middle estimate off by 6.0-fold (0.78 log units), on the high side; the measured number lies below the stated range.
By their numbers in this assay, from the lowest: compound 3; then compound 2; then compound 1.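

With the aryl part held constant, this position, between two ring nitrogen atoms on the shared core, now has its first single-change step: diallylamino in place of (1-methylbutyl)amino reads a 2.1-fold lower number from compound 2 to compound 3 (0.33 log units; beyond the scatter) in this assay and is modest in size. Removing the hydrogen-bond donor at this position therefore does not raise the number, so in this pair a low number does not depend on that donor, and an amine carrying two double bonds outside aromatic rings is accepted here. No measurement at hand gives a reason for this step.

On these data alone, it remains open whether the lower number goes with the loss of the hydrogen-bond donor or with the double bonds of diallylamino, and a saturated dipropylamino group on the same aryl part would separate these two readings. Compound 1 carries diethylamino but also differs in the aryl part, so the contribution of that aryl part, and the reach of this step to other aryl parts, cannot yet be read from the series.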